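This account rests on a few compounds, and the source may have more. Where it says the series, first, only, none or still open, it means among the compounds named here.

Of the compounds shown here, three built on a shared core have been tested in a functional assay on A549 cells (Homo sapiens) for cytotoxicity, read by MTT assay, with a stated time of 48 h; a lower number here means a stronger inhibitor, a higher number a weaker inhibitor. Among the measured compounds shown here, compound 2 `Cc1cccc(Cn2cc(COc3ccc4c(=O)ccoc4c3)nn2)c1` gives 20300 nM, the only actual number among the three. Compound 1 `O=c1ccoc2cc(OCc3cn(Cc4ccccc4)nn3)ccc12` reaches only the limit > 100000 nM. Compound 3 `O=c1ccoc2cc(OCc3cn(Cc4ccc([N+](=O)[O-])cc4)nn3)ccc12` likewise reaches only the limit > 100000 nM. Two of the three values thus sit at the limit of > 100000 nM in this assay, at which 2 of the 3 values shown sit. Compound 4 `N#Cc1cccc(Cn2cc(COc3ccc4c(=O)ccoc4c3)nn2)c1` is not yet measured; it differs from compound 2 by cyano in place of methyl on an aromatic carbon. The measured steps bear on it only loosely: an at least 4.9-fold lower number from compound 1 to compound 2 (0.69 log units; beyond the scatter), while an at least 4.9-fold higher number from compound 2 to compound 3 (0.69 log units; beyond the scatter), so both neighbours of compound 2 sit at the limit. For compound 4 the change is expected to bring a 3.0-fold higher number from compound 2 to compound 4 (0.47 log units; beyond the scatter). Compound 4 is estimated at 60000 nM, with a range from 15000 nM to 150000 nM.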

Compound 4, half-maximal inhibitory concentration: 14300 nM
Compound 4: middle estimate off by 4.2-fold (0.62 log units), on the high side, and the stated range ends above it.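

Methyl and cyano at this position cannot be told apart in this assay: the swap gives a 1.4-fold lower number from compound 2 to compound 4 (0.15 log units; within the scatter). Like methyl, cyano stands clear of the bare ring, with an at least 6.9-fold lower number from compound 1 to compound 4 (0.84 log units; beyond the scatter), and the 3-cyanophenyl stands clear of the 4-nitrophenyl, with an at least 6.9-fold lower number from compound 3 to compound 4 (0.84 log units; beyond the scatter). Both of these steps start from a limit of the assay, not from a number: the limit of > 100000 nM in this assay, at which 2 of the 4 values shown sit.

From the compounds shown here alone, whether an amine or a carboxylic acid on this carbon would give a value like those of methyl and cyano, or stay at the limit, remains open. Also open, going by these compounds, is whether a 4-cyanophenyl would behave like the 3-cyanophenyl or like the 4-nitrophenyl.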